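The compounds below may be only part of what the source reports. "The series", "measured", "known", "first", "only" and "open" are said of these compounds alone.

Of the compounds shown here, two have been measured in a functional assay on CCRF-CEM cells (Homo sapiens) for cytotoxicity, read by MTT assay, with a stated time of 72 h; a higher number here means a weaker inhibitor of growth, a lower number a stronger inhibitor of growth. Compound 1 `CC(C)COC(=O)Nc1ccc([Se][Se]c2ccc(NC(=O)OCC(C)C)cc2)cc1` gives 9800 nM, and compound 2 `CCCOC(=O)Nc1ccc([Se]C#N)cc1` gives 9300 nM. Compound 2 has the lowest of the two numbers, but its number and that of compound 1 lie within the scatter of each other, so the two show the same potency as far as these measurements can tell. Compound 3 `N#C[Se]c1ccc(NC(=O)OCc2ccccc2)cc1` is compound 2 with one change: phenyl in place of ethyl on a saturated chain carbon bound to an oxygen next to a carbonyl group. Within the data shown here, no measured pair differs at this place, so the data give no direct guide to the size of this step. The rest of the structure is unchanged, and the two measured compounds, which differ at other places, sit close together. A step of a 1.2-fold lower number from compound 2 to compound 3 (0.09 log units; within the scatter) is therefore expected, none beyond the scatter. Compound 3 is estimated at 7500 nM, with a range from 3000 nM to 20000 nM.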

Compound 3, concentration for 50% growth inhibition: 23200 nM
Beside the measured number, compound 3's estimate is 3.1-fold (0.49 log units) below it; measured number above the stated range.
By their numbers in this assay, from the lowest: compounds 2 and 1 (each within the scatter of the next); then compound 3.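

In this assay, phenyl in place of ethyl on a saturated chain carbon bound to an oxygen next to a carbonyl group gives a 2.5-fold higher number from compound 2 to compound 3 (0.40 log units; beyond the scatter). This place is therefore not indifferent to the group it carries: here, the larger group with an aromatic ring goes with weaker growth inhibition, although the step is modest and rests on a single pair of compounds. Nothing measured here accounts for the shift.

Going by these compounds, it remains open whether the ring itself matters or simply the added atoms, which a longer chain such as hexyl at this place could help to separate. Also open, on these data alone, is how an amine or a carboxylic acid on the phenyl ring would shift the number.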